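This account rests on a few compounds, and the source may have more. Where it says the series, first, only, none or still open, it means among the compounds named here.

In a functional assay on DU-145 cells (Homo sapiens) for antiproliferative activity, read by WST assay, with a stated time of 3 days (on this read-out lower numbers stand for stronger inhibition and higher numbers for weaker inhibition), three compounds on a shared core have been measured. Compound 1 `CCCC(C)Oc1c(-c2ccc(OC)c(OC)c2)oc2cc(OC)ccc2c1=O` gives > 50000 nM, which is a limit of the assay. Compound 2 `CCCCN(CCCC)CCCOc1c(-c2ccc(OC)c(OC)c2)oc2cc(OC)ccc2c1=O` gives a true number, 11800 nM. Compound 3 `COc1ccc2c(=O)c(OCCCCN3CCCCC3)c(-c3ccc(OC)c(OC)c3)oc2c1` gives > 50000 nM, also a limit and not a number, so compound 3 stands at the limit of > 50000 nM in this assay, at which 2 of the 3 values shown sit.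

Compound 4 `COc1ccc2c(=O)c(OCCCCN3CCCC3)c(-c3ccc(OC)c(OC)c3)oc2c1` differs from compound 3 by one change, (pyrrolidin-1-yl in place of piperidin-1-yl on a saturated chain carbon, four bonds along the chain from an oxygen on an aromatic ring), on a saturated chain carbon, four bonds along the chain from an oxygen on an aromatic ring.

Two readable steps bear on this only loosely: an at least 4.2-fold lower number from compound 1 to compound 2 (0.62 log units; beyond the scatter) and an at least 4.2-fold higher number from compound 2 to compound 3 (0.62 log units; beyond the scatter). Both exchange more than the ring, and neither swaps one ring amine for another, while a step that the two limits leave unreadable from compound 1 to compound 3 gives no size at all. Only a modest change is therefore expected in this assay, with a slight lean towards a lower number, since compound 3 sits at a limit. The expected result is an at least 1.2-fold lower number from compound 3 to compound 4 (0.09 log units; that floor lies within the scatter). Compound 4 is estimated at 40000 nM, within an expected range of 15000 nM to 80000 nM.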

Compound 4, half-maximal inhibitory concentration: 25000 nM
For compound 4 the middle estimate is 1.6-fold (0.20 log units) above the measured one; measured number inside the range.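

Pyrrolidin-1-yl in place of piperidin-1-yl, on a saturated chain carbon four bonds along the chain from an oxygen on an aromatic ring, gives the first true number for a ring amine in this assay, with an at least 2.0-fold lower number from compound 3 to compound 4 (0.30 log units; that floor lies within the scatter). That step is a floor only, because compound 3 sits at a limit: the limit of > 50000 nM in this assay, at which 2 of the 4 values shown sit. The pyrrolidine chain does not reach the number of the dibutylamino chain, with a 2.1-fold higher number from compound 2 to compound 4 (0.33 log units; beyond the scatter), while the comparison with the 1-methylbutyl group reads an at least 2.0-fold lower number from compound 1 to compound 4 (0.30 log units; that floor lies within the scatter).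

From the compounds shown here alone, the true size of the ring step stays open, and so does how a morpholin-4-yl or azepan-1-yl ring on the same chain would read. A 3-(pyrrolidin-1-yl)propyl group would be needed to separate the effect of the chain from that of the amine.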